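Chloro in place of methyl on the anilide ring of compound 2

The source may hold more compounds than are shown below. What is called first, only, known or untested is meant among the compounds shown, and "the series" means these compounds.

Measured so far:
compound 1, `COc1ccc(Cc2nnc(CN(c3cccc(C(F)(F)F)c3C)S(=O)(=O)c3ccc(C)cc3)o2)cc1`, gives 398 nM in a functional assay on CHO cells for antagonist activity at prostaglandin E2 receptor EP1 subtype (Homo sapiens), read by FLIPR and calcium flux; a lower number here means a stronger inhibitor, a higher number a weaker inhibitor
compound 2, `COc1ccc(Cc2nnc(CN(c3cccc(Cl)c3C)S(=O)(=O)c3ccc(C)cc3)o2)cc1`, gives 39.8 nM in this assay

Within the data shown here, compound 2 holds the lower of the two numbers in this assay; the single measured step is a 10-fold lower number from compound 1 to compound 2 (1.00 log units; beyond the scatter). Compound 3, `COc1ccc(Cc2nnc(CN(c3cccc(Cl)c3Cl)S(=O)(=O)c3ccc(C)cc3)o2)cc1`, differs from compound 2 thus: chloro in place of methyl on an aromatic carbon. Among the measured compounds shown here, no measured step covers a chloro for methyl exchange; the known step concerns trifluoromethyl to chloro and does not bear on it directly. For compound 3 the estimate in this assay is therefore 40 nM, range 15 nM to 125 nM. The expected step is a 1.0-fold higher number from compound 2 to compound 3 (0.00 log units; within the scatter), not beyond the scatter.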

Compound 3, inhibition constant: 39.8 nM
Beside the measured number, compound 3's estimate is 1.0-fold (0.00 log units) above it, within the range that was stated.
By their numbers in this assay, from the lowest: compounds 2 and 3 (each within the scatter of the next); then compound 1.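

In this assay, chloro replaces methyl on the aromatic carbon ortho to a chloro group with no change at the digits printed from compound 2 to compound 3 (within the scatter), so this position takes either group without a shift beyond the scatter. The 2,3-dichlorophenyl group in place of 2-methyl-3-(trifluoromethyl)phenyl gives a 10-fold lower number from compound 1 to compound 3 (1.00 log units; beyond the scatter), matching the size of the earlier step. No evidence at hand accounts for these results. Still open, on these data alone, is how a methoxy, a nitrile or an amine would fare at this position. As far as these compounds go, whether bromo or a longer chain such as ethyl would hold the number also remains unknown.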